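Shifting a Substituent Around the Benzyl Ring

The source may hold more compounds than are shown below. What is called first, only, known or untested is meant among the compounds shown, and "the series" means these compounds.

Compound 1 `COc1cccc(OC)c1OCCNCCOc1ccccc1OCc1ccccc1Cl` is tested in a functional assay on thoracic aorta for antagonist activity at Alpha-1D adrenergic receptor (Rattus norvegicus) (a lower number here means a less potent compound, a higher number a more potent compound, by a factor of ten per unit of this negative logarithm), where compound 1 gives 8.59. Compound 2 `COc1cccc(OC)c1OCCNCCOc1ccccc1OCc1cccc(Cl)c1` gives 8.72, and compound 3 `COc1cccc(OC)c1OCCNCCOc1ccccc1OCc1ccccc1C` gives 8.64. Compound 1 stands lowest of the three numbers, yet every gap between them lies within the scatter, so no order can be read from them. Compound 4 `COc1cccc(OC)c1OCCNCCOc1ccccc1OCc1ccc(C)cc1` differs from compound 1 by 4-methylphenyl in place of 2-chlorophenyl on a saturated chain carbon bound to an oxygen on an aromatic ring. Within the data shown here, two measured steps bear on this change: a number 0.13 log units higher from compound 1 to compound 2 (within the scatter), and a number 0.05 log units higher from compound 1 to compound 3 (within the scatter). Neither relocating the chloro nor exchanging it for methyl moved the number beyond the scatter, so a step of only a number 0.06 log units higher from compound 1 to compound 4 (within the scatter) is expected. Compound 4 is therefore estimated at 8.65, with a range from 8.3 to 9.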

Compound 4, negative logarithm of the antagonist equilibrium constant: 9.12
Compound 4: middle estimate off by 0.47 log units, on the low side; the whole stated range lies below it.
By their numbers in this assay, from the lowest: compounds 1, 3 and 2 (each within the scatter of the next); then compound 4.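

Moving the methyl alone, with 4-methylphenyl in place of 2-methylphenyl (a number 0.48 log units higher from compound 3 to compound 4 (beyond the scatter)), shows that at this position the place of the substituent on the ring can change the number beyond the scatter. Compound 4 also stands clear of both chloro compounds (a number 0.53 log units higher from compound 1 to compound 4 (beyond the scatter); a number 0.40 log units higher from compound 2 to compound 4 (beyond the scatter)), making it the most potent of the four. Nothing shown here explains this gain.

On these data alone, whether 4-chlorophenyl would match 4-methylphenyl remains open. So does how 4-methoxyphenyl or an unsubstituted phenyl would compare at this position.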